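Methyl on the Amide Nitrogen: From Compound 3 to Compound 4

The source may report more compounds than this note shows. Statements on the series, on what has been measured and on what is new or still open speak of the compounds shown alone.

Measured compounds:
- compound 1, `CN1C/C(=C\c2ccc(Br)cc2)C(=O)[C@]2(C1)[C@@H](c1ccc(Br)cc1)CN(C)[C@@]21C(=O)N(C)c2ccccc21`: 83.5%
- compound 2, `CN1C/C(=C\c2ccc(F)cc2)C(=O)[C@]2(C1)[C@@H](c1ccc(F)cc1)CN(C)[C@@]21C(=O)N(C)c2ccccc21`: 27.2%
- compound 3, `Cc1ccc(/C=C2\CN(C)C[C@@]3(C2=O)[C@@H](c2ccc(C)cc2)CN(C)[C@@]32C(=O)Nc3ccccc32)cc1`: 22.1%

In a functional assay on the whole organism (strain Wister albino) for inhibition, with Rattus norvegicus as the target, read by paw edema, with stated times of 1 h and 24 h, at a dose of 50 mg/kg by the intraperitoneal route (on this read-out higher numbers stand for more inhibition at the one dose given (going by the name of the read-out) and lower numbers for less inhibition), compound 1 gives 83.5%, compound 2 gives 27.2% and compound 3 gives 22.1%. Compound 3 stands lowest of the three numbers; its nearest neighbour is compound 2, whose value lies within the scatter of that of compound 3, so no order can be drawn between these two. Compound 1 lies far beyond the scatter above compound 3.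

Compound 4, `Cc1ccc(/C=C2\CN(C)C[C@@]3(C2=O)[C@@H](c2ccc(C)cc2)CN(C)[C@@]32C(=O)N(C)c3ccccc32)cc1`, differs from compound 3 in one place: methyl in place of hydrogen on an amide-type nitrogen in a ring. Going by the values given here, no pair of measured compounds shows this step on its own, as compound 1 and compound 2 differ from compound 3 in the aryl substituent as well. Compound 2, which carries the methyl on the amide-type nitrogen, sits within the scatter of compound 3, while compound 1 sits far above it, so the data give no clean guide.

The author expects for compound 4 a value of 35%, between 15% and 65%, a step of a number 12.9 percentage points higher from compound 3 to compound 4 (beyond the scatter) that is expected to be small, upward if at all, and possibly within the scatter.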

Compound 4, a percentage reported as inhibition, in the whole organism at one dose (the size of the read-out at that dose, not a potency): 57%
Compound 4: the middle estimate sits 22 percentage points below what was measured; the measured number falls inside the stated range.
By their numbers in this assay, from the lowest: compounds 3 and 2 (each within the scatter of the next); then compound 4; then compound 1.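

In this assay, going by these compounds alone, methyl in place of hydrogen on the amide-type nitrogen gives a number 34.9 percentage points higher from compound 3 to compound 4 (beyond the scatter) with the aryl substituent unchanged, so this change can now be read on its own for the first time. The step shows that this position, two ring bonds from the ring atom that bears two fused rings, is not indifferent to a single added carbon, and that replacing the amide hydrogen raises the number at this dose by a large amount. Nothing measured here bears on why the number rises.

On these data alone, whether an ethyl group, a longer chain or a benzyl group on the same nitrogen would go further remains open. Also open, as far as these compounds go, is whether the methyl step would be of the same size with the bromophenyl and fluorophenyl groups of compound 1 and compound 2.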